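Naphthalen-2-yl in place of pyridin-3-yl on a shared core

A few compounds are considered here, and "the series" means these few. Any claim that something is new, unique, unknown or untested is made for them only; others in the source may bear on it.

Compound 1 `CC(C)c1nn(-c2ccc(C(N)=O)c(N[C@H]3CC[C@H](O)CC3)c2)c2nccc(-c3cccnc3)c12` gives the lowest number of the two measured, 464 nM in a functional assay on SK-BR-3 cells (Homo sapiens) for inhibition, read by CellTiter-Glo, with a stated time of 72 h; a lower number here means a stronger inhibitor, a higher number a weaker inhibitor. Compound 2 `CC(C)c1nn(-c2ccc(C(N)=O)cc2)c2nccc(-n3cnc(-c4cnn(C)c4)c3)c12` gives 1640 nM in this assay, a gap beyond the scatter. Compound 3 `CC(C)c1nn(-c2ccc(C(N)=O)c(N[C@H]3CC[C@H](O)CC3)c2)c2nccc(-c3ccc4ccccc4c3)c12` differs from compound 1 in one place: naphthalen-2-yl in place of pyridin-3-yl on an aromatic carbon. Going by the values given here, no measured pair shows this change, so its size is unknown from the data. A modest step toward a weaker inhibitor is expected, a 1.9-fold higher number from compound 1 to compound 3 (0.29 log units; within the scatter). Compound 3 is estimated at 900 nM, within a range from 250 nM to 3500 nM.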

Compound 3, half-maximal inhibitory concentration: > 10000 nM
Compound 3 gave a limit, no number (the forecaster's own chance of this, stated with the estimate: 5%); at least 11-fold (1.04 log units) between middle value and limit.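

In this assay compound 3 gives > 10000 nM, which is a limit of the assay and not a number. On this aromatic carbon of the shared core, naphthalen-2-yl in place of pyridin-3-yl is a large change, with an at least 21-fold higher number from compound 1 to compound 3 (1.33 log units; beyond the scatter), so this position does not treat the two aromatic groups alike. The step is a bound rather than a measured size: the limit of > 10000 nM in this assay, at which 1 of the 3 values shown sits.

The compounds shown leave open whether the nitrogen of pyridin-3-yl or the second ring of naphthalen-2-yl matters more here. Phenyl on this carbon would separate the two, and how a small amine would fare here also remains open.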